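Replacing the Benzylamine Arm with a Piperidinylpropyl Chain

The compounds below may be only part of what the source reports. "The series", "measured", "known", "first", "only" and "open" are said of these compounds alone.

Among the measured compounds shown here, of the two numbers measured so far in an assay on HEK293 cells for inhibition of Steryl-sulfatase (Homo sapiens), tested at 1 uM (on this read-out lower numbers stand for a weaker effect and higher numbers for a stronger effect at the one concentration tested), compound 2 `CCCN(Cc1ccccc1)c1ccc(C(=O)N2CCc3ccc(OS(N)(=O)=O)cc3C2)cc1` gives 94.3% and compound 1 `CCN(Cc1ccncc1)c1ccc(C(=O)N2CCc3ccc(OS(N)(=O)=O)cc3C2)cc1` gives 86.6%; the difference a number 7.7 percentage points higher from compound 1 to compound 2 (within the scatter) is within the scatter, so the two cannot be told apart. Compound 3 `CN(CCCN1CCCCC1)c1ccc(C(=O)N2CCc3ccc(OS(N)(=O)=O)cc3C2)cc1` has not yet been measured; it differs from compound 2 by methyl(3-(piperidin-1-yl)propyl)amino in place of benzyl(propyl)amino on an aromatic carbon. For the measured compounds named here, only one measured step touches this same position, and that change a number 7.7 percentage points higher from compound 1 to compound 2 (within the scatter) stayed within the scatter. A similarly small step, perhaps slightly downward, is therefore expected for a number 8.3 percentage points lower from compound 2 to compound 3 (within the scatter). Compound 3 is estimated at 86%, between 68% and 96%.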

Compound 3, a percentage reported as inhibition, at one concentration (the size of the read-out at that concentration, not a potency): 40.7%
Beside the measured number, compound 3's estimate is 45.3 percentage points above it, and the stated range ends above it.
By their numbers in this assay, from the lowest: compound 3; then compounds 1 and 2 (each within the scatter of the next).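

In this assay, the new arm gives a number 53.6 percentage points lower from compound 2 to compound 3 (beyond the scatter) and a number 45.9 percentage points lower from compound 1 to compound 3 (beyond the scatter), so this aromatic carbon is far less tolerant of change than the first two compounds suggested. The arms of compound 2 and compound 3 have equal heavy-atom counts, so that count alone does not track the drop; the aromatic ring gives way to a non-aromatic ring with a second nitrogen in the arm. Nothing available explains the drop. Which part of the arm goes with the drop stays open: the piperidin-1-yl ring, the propyl chain or the methyl. A cyclohexyl or morpholine ring on the same chain would help separate these.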